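This account rests on a few compounds, and the source may have more. Where it says the series, first, only, none or still open, it means among the compounds named here.

Compound 1 `C=CCN(CCC)C(=O)c1c(C)nc2n1CCCN2c1c(C)cc(C)cc1C`: in an in vitro assay on IMR-32 cells for displacement of a labelled ligand from corticotropin-releasing factor receptor 1 (Homo sapiens) (a lower number here means a stronger inhibitor, a higher number a weaker inhibitor), compound 1 gives > 5000 nM, which is a limit of the assay rather than a number.
Compound 2 `CCCN(Cc1c(C(F)(F)F)nc2n1CCCN2c1c(C)cc(C)cc1C)CC1CC1`: in this assay compound 2 gives 32 nM.
Compound 3 `CCCN(CC1CC1)C(=O)c1c(C)nc2n1CCC(=O)N2c1c(C)cc(C)cc1C`: in this assay compound 3 gives > 5000 nM, again only a limit of the assay.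

Compound 2 is thus the only one of the three with an actual number; the other two sit at the limit of > 5000 nM in this assay, at which 2 of the 3 values shown sit. No two of the measured compounds differ in just one place, so nothing measured here tells how far a single change moves the result.

Compound 4 `Cc1cc(C)c(N2CCCn3c2nc(C(F)(F)F)c3CN2CCCN(C)CC2)c(C)c1` is built from compound 2 by one change: 4-methyl-1,4-diazepan-1-yl in place of (cyclopropylmethyl)(propyl)amino on a saturated chain carbon bound to an aromatic carbon. Both groups carry the same count of heavy atoms, but the entering ring brings a second nitrogen where the leaving group had a small carbon ring and a straight chain. Without a measured step to lean on, the expectation is a loss of binding, clearly beyond the scatter, in the step from compound 2 to compound 4 a 9.4-fold higher number from compound 2 to compound 4 (0.97 log units; beyond the scatter). Compound 4 is expected to give 300 nM in this assay, somewhere from 60 nM to 2000 nM.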

Compound 4, inhibition constant: > 5000 nM
Compound 4 was reported as a limit (the forecaster's own chance of this, stated with the estimate: 20%); middle value at least 16-fold (1.22 log units) away from the limit.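

Going by these compounds alone, this is the first measured step in the set, and it shows that binding depends strongly on the amine at this place, on a saturated chain carbon bound to an aromatic carbon: in this assay, 4-methyl-1,4-diazepan-1-yl in place of (cyclopropylmethyl)(propyl)amino gives an at least 150-fold higher number from compound 2 to compound 4 (2.19 log units; beyond the scatter). The two groups carry the same count of heavy atoms, so that count alone does not decide binding here. The true size of the step stays unknown, as compound 4 gives only a limit of the assay: the limit of > 5000 nM in this assay, at which 3 of the 4 values shown sit.

This single step cannot separate the effect of the seven-membered ring from that of the second nitrogen. On these data alone, whether a piperidine, with a smaller ring and no second nitrogen, or a morpholine, with oxygen in its ring, would keep binding remains open.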